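Acetylation of the benzylic hydroxyl in compound 3

This account rests on a few compounds, and the source may have more. Where it says the series, first, only, none or still open, it means among the compounds named here.

Measured so far:
Compound 1, `NC(=O)c1c[nH]c([C@@H](O)c2ccccc2)cc1=O`: in a functional assay on A549 cells (Homo sapiens) for inhibition, read by sulforhodamine B assay, with a stated time of 48 h (a higher number here means a weaker inhibitor, a lower number a stronger inhibitor), compound 1 gives > 50000 nM, a limit of the assay and not a number.
Compound 2, `COC(=O)c1c[nH]c([C@@H](O)c2ccccc2)cc1=O`: in this assay compound 2 gives > 50000 nM, again only a limit.
Compound 3, `NC(=O)c1cn(CCO)c([C@@H](O)c2ccccc2)cc1=O`: in this assay compound 3 gives > 50000 nM, likewise a limit.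

Compound 3 therefore stands at the same limit as the other two measured compounds; no number places it above or below them. The two measured single-point steps, a step that the two limits leave unreadable from compound 1 to compound 2 and a step that the two limits leave unreadable from compound 1 to compound 3, cannot be read in size or direction, since both ends sit at the limit of > 50000 nM in this assay, at which 3 of the 3 values shown sit.

The next compound, compound 4, `CC(=O)O[C@@H](c1ccccc1)c1cc(=O)c(C(N)=O)cn1CCO`, differs from compound 3 by acetyl in place of hydrogen on an oxygen on a saturated carbon. Neither measured step touches this oxygen, so nothing in the series bears directly on the change, and the steps that exist are unreadable anyway. With every measured value at the limit, the expectation for a step that the limit leaves unreadable from compound 3 to compound 4 is no step beyond the scatter, and compound 4 is most likely to return a limit too. The estimate for compound 4 in this assay is 60000 nM, within 20000 nM to 200000 nM.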

Compound 4, half-maximal inhibitory concentration: > 50000 nM
Compound 4 gave a limit, no number; the forecaster's own chance of this, stated with the estimate: 80%; the middle value does not contradict the limit.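

In this assay compound 4 gives > 50000 nM, a limit and not a number. The change from compound 3 to compound 4 therefore cannot be read in size or direction, and the series still gives no readable step: the limit of > 50000 nM in this assay, at which 4 of the 4 values shown sit.

The compounds shown leave open which change to the shared core, if any, would give a measurable value in this assay.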